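Removing the Fluorine From Compound 2

A few compounds are considered here, and "the series" means these few. Any claim that something is new, unique, unknown or untested is made for them only; others in the source may bear on it.

Of the compounds shown here, two have been tested in a functional assay on HT-29 cells (Homo sapiens) for cytotoxicity, read by MTT assay, with a stated time of 2 days, tested at 10 uM; a lower number here means less inhibition, a higher number more inhibition at the concentration tested (going by the name of the read-out). Compound 1, `CCCCNc1nc(NCc2ccco2)c2cc(F)ccc2n1`, gives 88.1%. Compound 2, `Cc1cccc(N2CCN(CCCCNc3nc(NCc4ccco4)c4cc(F)ccc4n3)CC2)c1C`, gives 96.1%. Compound 2 has the higher of the two numbers, but the gap to compound 1 lies within the usual scatter of this measurement, so the two cannot be told apart on these data. Among the measured compounds shown here, compound 1 and compound 2 differ in more than one place, so no single-site step between measured compounds can be read from them.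

Compound 3, `Cc1cccc(N2CCN(CCCCNc3nc(NCc4ccco4)c4ccccc4n3)CC2)c1C`, is the untested relative of compound 2. The change is hydrogen in place of fluoro on an aromatic carbon. Nothing measured here shows how such a swap of fluoro for hydrogen shifts the read-out in this assay. The expectation is therefore a step of a number 4.1 percentage points lower from compound 2 to compound 3 (within the scatter), which means none beyond the scatter. Compound 3 is estimated at 92%, with a range from 80% to 99%.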

Compound 3, a percentage reported as inhibition, at one concentration (the size of the read-out at that concentration, not a potency): 94.2%
Estimate against measurement, compound 3: 2.2 percentage points below; low and high end bracket the measured number.
By their numbers in this assay, from the lowest: compounds 1, 3 and 2 (each within the scatter of the next).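

Among the compounds shown here, the pair compound 2 and compound 3 gives the first comparison in this assay that differs in one place only, and the change of fluoro to hydrogen on the six-membered aromatic ring of carbon only comes to a number 1.9 percentage points lower from compound 2 to compound 3 (within the scatter) and no more. At this position, then, the fluoro is not needed for this pair to keep a high read-out, a point that compound 1 and compound 2 could not show because they differ in more than one place. Nothing measured here offers an explanation for this outcome. Still, a percentage at one concentration is not a potency, so a difference between these two compounds at lower concentrations remains possible. Also open, from the compounds shown here alone, is whether a chloro, a methoxy or an amine at this position would shift the read-out, and whether removing the fluoro from compound 1 would give the same result.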